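Amide series: removing the aryl group from the chain

The source may hold more compounds than are shown below. What is called first, only, known or untested is meant among the compounds shown, and "the series" means these compounds.

Compound 1 `Cc1cccc(Cn2cc(C(N)=O)c3c(N)ncnc32)c1` carries a carboxamide on the shared core and a 3-methylbenzyl group on the aromatic nitrogen. In a functional assay on KB cells (Homo sapiens) for cytotoxicity (a higher number here means a weaker inhibitor, a lower number a stronger inhibitor), compound 1 reports only a limit, > 100000 nM, so its true value is not known; it sits at the limit of > 100000 nM in this assay, at which 1 of the 3 values shown sits. Compound 2 `Cc1cccc(Cn2cc(C(=N)S)c3c(N)ncnc32)c1` gives 30000 nM and compound 3 `NC(=S)c1cn(Cc2ccccc2)c2ncnc(N)c12` gives 32000 nM, two values within the scatter of each other. For the measured compounds named here, the one measured step, an at least 3.3-fold lower number from compound 1 to compound 2 (0.52 log units; beyond the scatter), concerns the thioamide in place of the carboxamide and says nothing about the substituent on the chain carbon.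

Compound 4 `C=CCn1cc(C(N)=O)c2c(N)ncnc21` differs from compound 1 by vinyl in place of 3-methylphenyl on a saturated chain carbon bound to an aromatic nitrogen. Going by the values given here, no measured step bears on this change; the comparison of compound 2 with compound 3 only shows that a methyl on the aryl ring leaves the number where it was. With compound 1 already at a limit, compound 4 is expected to stay weak, with an expected step that the limit leaves unreadable from compound 1 to compound 4. Compound 4 is estimated at 150000 nM, within 50000 nM to 500000 nM, and most likely another limit.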

Compound 4, half-maximal inhibitory concentration: 100000 nM
Compound 4: the middle estimate sits 1.5-fold (0.18 log units) above what was measured; measured number inside the range.
By their numbers in this assay, from the lowest: compounds 2 and 3 (each within the scatter of the next); then compound 4.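

In this assay, vinyl in place of 3-methylphenyl on a saturated chain carbon bound to an aromatic nitrogen gives a number no higher from compound 1 to compound 4 (the limit leaves the size open). Compound 4 gives 100000 nM, so the carboxamide series now holds a number that is not a limit, and the 3-methylphenyl group can leave the chain without the number rising. The value of compound 1 is a limit, and the size of this step stays open because of it: the limit of > 100000 nM in this assay, at which 1 of the 4 values shown sits.

Open, as far as these compounds go, is whether vinyl on the chain carbon would leave the number unchanged with the thioamide of compound 3 on the shared core. Also open, from the compounds shown here alone, is what an amine or a carboxylic acid on the chain carbon, or a longer chain, would do to the number in this assay.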